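The source may report more compounds than this note shows. Statements on the series, on what has been measured and on what is new or still open speak of the compounds shown alone.

Of the compounds shown here, two have been measured in an assay on isolated protein for inhibition of Amine oxidase [flavin-containing] A (Homo sapiens); a lower number here means a stronger inhibitor, a higher number a weaker inhibitor. Compound 1 `CCN(CCCCCCOc1ccc(C(=O)/C=C/c2ccc(N(C)C)cc2)c(O)c1)Cc1ccccc1OC` gives 54300 nM in this assay. Compound 2 `CCN(CCCOc1ccc(C(=O)/C=C/c2ccccc2)c(O)c1)Cc1ccccc1N(C)C` gives 67800 nM in this assay. The two numbers lie within the usual scatter of one another, so neither compound stands apart from the other, and both are weak inhibitors.

Compound 3 `CCN(CCCCCCOc1ccc(C(=O)/C=C/c2ccc(N(C)C)cc2)c(O)c1)Cc1ccc(N(C)C)cc1` has not yet been measured. It differs from compound 1 in one place: 4-(dimethylamino)phenyl in place of 2-methoxyphenyl on a saturated chain carbon bound to an amine nitrogen. Among the measured compounds shown here, no step between measured compounds shows how a change of this kind affects this assay, so the expectation rests on the two values alone, both of which sit in the same weak range. The change from compound 1 to compound 3 is expected to give a step of a 1.1-fold lower number from compound 1 to compound 3 (0.04 log units; within the scatter), which is no larger than the scatter. Compound 3 is therefore expected to give about 50000 nM in this assay, with a likely range from 15000 nM to 150000 nM.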

Compound 3, half-maximal inhibitory concentration: 53600 nM
Compound 3: the middle estimate sits 1.1-fold (0.03 log units) below what was measured, and the stated range covers the measured number.
By their numbers in this assay, from the lowest: compounds 3, 1 and 2 (each within the scatter of the next).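

Among the compounds shown here, putting 4-(dimethylamino)phenyl in place of 2-methoxyphenyl on a saturated chain carbon bound to an amine nitrogen gives a 1.0-fold lower number from compound 1 to compound 3 (0.01 log units; within the scatter) in this assay, the first step that can be read at this position. The step lies within the scatter, so in this pair the two substituted rings cannot be told apart, even though the group and its position on the ring both differ. Nothing measured here explains this result.
Going by these compounds, it remains open whether any group at this position can move the number beyond the scatter, as a plain benzyl, a 4-fluorobenzyl or a pyridylmethyl group might show. On these data alone, the effect of chain length also remains open, as compound 1 and compound 2 differ in more than one place.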